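A few compounds are considered here, and "the series" means these few. Any claim that something is new, unique, unknown or untested is made for them only; others in the source may bear on it.

Series notes. Compound 1 `COC(=O)[C@@]1(C)CCC=C2[C@@H]1CC[C@@H](C)[C@]2(C)Cc1c[nH]c2ccc(Br)cc12` carries a bromo group on the indole ring; in a functional assay on T47D cells (Homo sapiens) for inhibition, read by sulforhodamine B assay, with a stated time of 48 h (on this read-out higher numbers stand for weaker inhibition of growth and lower numbers for stronger inhibition of growth), compound 1 gives 16000 nM. Compound 2 `COC(=O)[C@@]1(C)CCC=C2[C@@H]1CC[C@@H](C)[C@]2(C)Cc1c[nH]c2ccc(F)cc12` differs by fluoro in place of bromo on an aromatic carbon, and in this assay compound 2 gives 3900 nM. Among the measured compounds shown here, the step of a 4.1-fold lower number from compound 1 to compound 2 (0.61 log units; beyond the scatter) is the only measured step so far, and compound 2 holds the lowest of the two numbers, its nearest neighbour being compound 1.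

Compound 3 `COC(=O)[C@@]1(C)CCC=C2[C@@H]1CC[C@@H](C)[C@]2(C)Cc1c[nH]c2ccc(OC)cc12` is not yet measured. It differs from compound 2 by methoxy in place of fluoro on an aromatic carbon. For the measured compounds named here, no measured step bears on this change: the one known step swaps one halogen for another, whereas here a methoxy group enters. With nothing to anchor a direction, compound 3 is expected to stay near compound 2, with the step of a 1.3-fold higher number from compound 2 to compound 3 (0.11 log units; within the scatter) inside the scatter but with a wide range either way. The estimate for compound 3 in this assay is 5000 nM, between 1500 nM and 16000 nM.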

Compound 3, concentration for 50% growth inhibition: 3700 nM
For compound 3 the middle estimate is 1.4-fold (0.13 log units) above the measured one, and the stated range covers the measured number.
By their numbers in this assay, from the lowest: compounds 3 and 2 (each within the scatter of the next); then compound 1.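

In this assay, among the compounds shown here, the step of a 1.1-fold lower number from compound 2 to compound 3 (0.02 log units; within the scatter) puts a non-halogen at this aromatic carbon for the first time, and methoxy cannot be told apart from fluoro here, even though methoxy brings a hydrogen-bond acceptor that fluoro lacks. The step of a 4.3-fold lower number from compound 1 to compound 3 (0.64 log units; beyond the scatter) lies beyond the scatter, so bromo now stands apart from two different groups rather than from fluoro alone, and compound 1 is the weakest of the three. No supporting data bear on why fluoro and methoxy read alike or why bromo stands apart.

From the compounds shown here alone, it remains open whether an amine or a carboxylic acid at this position would shift the number beyond the scatter, and whether a longer alkoxy chain would keep the level of compound 2 and compound 3. The effect of the unsubstituted parent on this read-out is also unresolved.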